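The source may hold more compounds than are shown below. What is called first, only, known or untested is meant among the compounds shown, and "the series" means these compounds.

Two compounds share one core and differ only in the group on the carbonyl carbon. Compound 1 `O=C(N1CCCCC1)N1CC(c2nc(-c3cccc(Cl)c3)no2)C1` carries piperidin-1-yl there, and in an assay on HEK293 cells for positive allosteric modulation of metabotropic glutamate receptor 5 (Homo sapiens), read by FLIPR (a higher number here means that more compound is needed for the effect, a lower number that less compound is needed), compound 1 gives 370 nM. Compound 2 `O=C(c1cccc(F)c1)N1CC(c2nc(-c3cccc(Cl)c3)no2)C1` carries 3-fluorophenyl instead. In this assay compound 2 reaches only a limit of the assay, > 10000 nM, so no number is known for it, only that it sits at the limit of > 10000 nM in this assay, at which 1 of the 2 values shown sits. Among the compounds with values here, the single measured step, an at least 27-fold higher number from compound 1 to compound 2 (1.43 log units; beyond the scatter), thus shows that exchanging piperidin-1-yl on the carbonyl for 3-fluorophenyl costs a great deal.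

Compound 3 `O=C(N1CCCCCC1)N1CC(c2nc(-c3cccc(Cl)c3)no2)C1` is not yet measured. It differs from compound 2 in one place: azepan-1-yl in place of 3-fluorophenyl on a carbonyl carbon. This change removes the group that went with the loss in the measured step and brings in a ring of the same family as the piperidin-1-yl of compound 1. A large downward step in this assay is therefore expected, roughly the measured step run backwards, so that compound 3 should land near compound 1. The estimate for compound 3 is 450 nM, with a range from 120 nM to 1800 nM. This corresponds to the expected step of an at least 22-fold lower number from compound 2 to compound 3 (1.34 log units; beyond the scatter).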

Compound 3, half-maximal effective concentration: 47 nM
The estimate for compound 3 lay 9.6-fold (0.98 log units) above the measured number; measured number outside the range, below it.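

In this assay, the group on the carbonyl carbon matters even among close relatives: going from piperidin-1-yl to azepan-1-yl gives a 7.9-fold lower number from compound 1 to compound 3 (0.90 log units; beyond the scatter), so the response at this position is not simply on or off between a phenyl ring and an amine ring. Exchanging 3-fluorophenyl for azepan-1-yl gives an at least 210-fold lower number from compound 2 to compound 3 (2.32 log units; beyond the scatter), even though both groups have the same number of heavy atoms, so that count alone does not separate a good group from a poor one here. This larger step is only a lower bound on the true size of the change, as compound 2 stands at a limit of the assay: the limit of > 10000 nM in this assay, at which 1 of the 3 values shown sits.

The compounds shown leave open whether the gain continues with a still larger ring such as azocan-1-yl, or whether a ring is needed at all, which an open-chain diethylamino group on the carbonyl carbon would test. They also leave open whether the poor result of compound 2 goes with its fluorine, with its phenyl ring, or with the absence of a nitrogen on the carbonyl carbon.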